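The source may hold more compounds than are shown below. What is called first, only, known or untested is meant among the compounds shown, and "the series" means these compounds.

Of the compounds shown here, three sharing one core have been measured. Compound 1 `Cc1nc(S(C)(=O)=O)ccc1Oc1ncnc(OC2CCN(C(=O)OC(C)C)CC2)c1F` gives 142 nM in a functional assay on isolated protein for inhibition of Glucose-dependent insulinotropic receptor (Rattus norvegicus), read by HTRF and cAMP accumulation; a lower number here means that less compound is needed, a higher number that more compound is needed for the effect. Compound 2 `Cc1nc(S(C)(=O)=O)ccc1Oc1ncnc(OC2CCN(C(=O)OC(C)(C)CF)CC2)c1F` gives 138 nM in this assay, and compound 3 `Cc1nc(S(C)(=O)=O)ccc1Oc1ncnc(OC2CCN(C(=O)OC(C)F)CC2)c1F` gives 315 nM. Going by the values given here, compound 2 has the lowest number of the three, but the step of a 1.0-fold lower number from compound 1 to compound 2 (0.01 log units; within the scatter) is within the scatter, so compounds 1 and 2 cannot be told apart; only the step of a 2.3-fold higher number from compound 2 to compound 3 (0.36 log units; beyond the scatter) stands beyond it, as does a 2.2-fold higher number from compound 1 to compound 3 (0.35 log units; beyond the scatter).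

Compound 4 `Cc1nc(S(C)(=O)=O)ccc1Oc1ncnc(OC2CCN(C(=O)O[C@@H](C)CF)CC2)c1F` is not yet measured. It differs from compound 2 by 1-(fluoromethyl)ethyl in place of 1-(fluoromethyl)-1-methylethyl on an oxygen next to a carbonyl group. The step that bears most directly on this change is a 2.3-fold higher number from compound 2 to compound 3 (0.36 log units; beyond the scatter), where the group on the same oxygen shrank to 1-fluoroethyl and the number rose modestly. The group entering in compound 4 is larger than 1-fluoroethyl and smaller than the group it replaces, so a step smaller than that one is expected, in the same direction or none beyond the scatter, giving a 1.3-fold higher number from compound 2 to compound 4 (0.12 log units; within the scatter). Compound 4 is therefore expected to give about 180 nM in this assay, between 90 nM and 360 nM.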

Compound 4, half-maximal effective concentration: 1680 nM
Beside the measured number, compound 4's estimate is 9.3-fold (0.97 log units) below it; the measured number lies above the stated range.
By their numbers in this assay, from the lowest: compounds 2 and 1 (each within the scatter of the next); then compound 3; then compound 4.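

In this assay, 1-(fluoromethyl)ethyl in place of 1-(fluoromethyl)-1-methylethyl gives a 12-fold higher number from compound 2 to compound 4 (1.09 log units; beyond the scatter), so a small change to the group on this oxygen can shift the number far more than any earlier step did. The number also does not simply follow the size of the group: a 5.3-fold higher number from compound 3 to compound 4 (0.73 log units; beyond the scatter) places 1-(fluoromethyl)ethyl above the smaller 1-fluoroethyl, although the largest group, in compound 2, gives the lowest number alongside compound 1. Fluoro in place of hydrogen gives a 12-fold higher number from compound 1 to compound 4 (1.07 log units; beyond the scatter), whereas fluoromethyl in place of hydrogen gave a 1.0-fold lower number from compound 1 to compound 2 (0.01 log units; within the scatter), so the effect of adding fluorine depends on the rest of the group.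

Nothing available explains this jump. Still open, as far as these compounds go, are how the mirror-image form of the stereocentre in compound 4 would read, and how a longer chain or an amine would read on this oxygen.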